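This account rests on a few compounds, and the source may have more. Where it says the series, first, only, none or still open, it means among the compounds named here.

Working notes on the series in a functional assay on MCF7 cells (Homo sapiens) for cytotoxicity, read by MTT assay, with a stated time of 48 h; on this read-out higher numbers stand for weaker inhibition and lower numbers for stronger inhibition. Three analogues share one core and differ only in the group on a double-bonded chain carbon bound to a double-bonded ring carbon. Compound 1 (`O=C1/C(=C\c2ccc(O)cc2)S/C(=N/c2ccccc2)N1Cc1ccncc1`) gives 18900 nM, compound 2 (`CC(C)c1ccc(/C=C2/S/C(=N/c3ccccc3)N(Cc3ccncc3)C2=O)cc1`) gives 53300 nM, and compound 3 (`O=C1/C(=C\c2cccc(Cl)c2)S/C(=N/c2ccccc2)N1Cc1ccncc1`) gives 29800 nM.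

Compound 3 stands within the scatter of both others, as shown by a 1.6-fold higher number from compound 1 to compound 3 (0.20 log units; within the scatter) and a 1.8-fold lower number from compound 2 to compound 3 (0.25 log units; within the scatter). Among the compounds with values here, the only step beyond the scatter is the modest 2.8-fold higher number from compound 1 to compound 2 (0.45 log units; beyond the scatter).

Compound 4 (`Cc1ccc(/C=C2/S/C(=N/c3ccccc3)N(Cc3ccncc3)C2=O)s1`) is next, with 5-methylthiophen-2-yl in place of 3-chlorophenyl on that same carbon: 5-methylthiophen-2-yl in place of 3-chlorophenyl on a double-bonded chain carbon bound to a double-bonded ring carbon. Within the data shown here, no measured compound carries a five-membered aromatic ring at this place, so the comparison is indirect. All three measured steps at this place are small, the largest being a 2.8-fold higher number from compound 1 to compound 2 (0.45 log units; beyond the scatter), so no step beyond the scatter is expected in this assay.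

The expected change is a 1.0-fold higher number from compound 3 to compound 4 (0.00 log units; within the scatter).

Compound 4 is estimated at 30000 nM, with an expected range of 14000 nM to 65000 nM.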

Compound 4, half-maximal inhibitory concentration: 28700 nM
Beside the measured number, compound 4's estimate is 1.0-fold (0.02 log units) above it; low and high end bracket the measured number.
By their numbers in this assay, from the lowest: compounds 1, 4, 3 and 2 (each within the scatter of the next, the first and the last beyond it).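

All three steps into 5-methylthiophen-2-yl on a double-bonded chain carbon bound to a double-bonded ring carbon lie within the scatter in this assay (a 1.0-fold lower number from compound 3 to compound 4 (0.02 log units; within the scatter)) and (a 1.9-fold lower number from compound 2 to compound 4 (0.27 log units; within the scatter)) and (a 1.5-fold higher number from compound 1 to compound 4 (0.18 log units; within the scatter)). Within the data shown here, the earlier compounds carried only six-membered aromatic rings of carbon at this place, whereas this five-membered aromatic ring with 1 hetero atom now sits within the scatter of all three, and the only step beyond the scatter remains (a 2.8-fold higher number from compound 1 to compound 2 (0.45 log units; beyond the scatter)). No supporting measurement bears on why this exchange of rings leaves the number within the scatter.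

The compounds shown leave open whether an amine, a carboxylic acid or a longer alkyl chain at this place would give a step beyond the scatter. They also leave open what the methyl on the thiophene contributes, since no unsubstituted thiophen-2-yl stands among them.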